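The compounds below may be only part of what the source reports. "The series", "measured", "known", "first", "only" and "open" are said of these compounds alone.

Measured in a functional assay on PC-12 cells (Rattus norvegicus) for cytotoxicity, read by MTT assay, with stated times of 2 h and 24 h, tested at 10 uM; a lower number here means a weaker effect, a higher number a stronger effect of the compound at the concentration tested:
- compound 1, `Cc1ccc(-n2nc(-c3ccc(C(F)(F)F)cc3O)nc2-c2ccccc2O)cc1`, gives 102%
- compound 2, `Oc1cc(C(F)(F)F)ccc1-c1nc(-c2ccccc2O)n(-c2ccc(I)cc2)n1`, gives 105%

Compound 2 and compound 1 lie within the scatter of each other, so neither can be called different from the other. Compound 3, `Oc1cc(C(F)(F)F)ccc1-c1nc(-c2ccccc2O)n(-c2cccc(C(F)(F)F)c2)n1`, is compound 2 with 3-(trifluoromethyl)phenyl in place of 4-iodophenyl on an aromatic nitrogen. For the measured compounds named here, the only measured step that bears on this, a number 3 percentage points higher from compound 1 to compound 2 (within the scatter), also swapped the group on that same aromatic nitrogen and stayed within the scatter, so the expected step of a number 2 percentage points lower from compound 2 to compound 3 (within the scatter) is none beyond the scatter. Compound 3 is estimated at 103%, in the range 90% to 116%.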

Compound 3, a percentage reported as activity, at one concentration (the size of the read-out at that concentration, not a potency): 99.9%
For compound 3 the middle estimate is 3.1 percentage points above the measured one; measured number inside the range.
By their numbers in this assay, from the lowest: compounds 3, 1 and 2 (each within the scatter of the next).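

In this assay, for the compounds shown here, a group with its substituent named at the 3-position now stands on the aromatic nitrogen, where the earlier compounds carried 4-substituted phenyl groups. Placing 3-(trifluoromethyl)phenyl there in place of 4-iodophenyl gives a number 5.1 percentage points lower from compound 2 to compound 3 (within the scatter), and in place of 4-methylphenyl it gives a number 2.1 percentage points lower from compound 1 to compound 3 (within the scatter). These three aryl groups therefore cannot be told apart at this position, and nothing at hand offers an explanation. As far as these compounds go, whether a phenyl group carrying an amine or a carboxylic acid on that nitrogen would stand apart from them remains open.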